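Trading the cyclopentyl cap for a trifluoromethylphenyl one

A few compounds are considered here, and "the series" means these few. Any claim that something is new, unique, unknown or untested is made for them only; others in the source may bear on it.

Compound 1 `Cc1cccc(Cn2c(CN3CCN(C(=O)c4ccc([N+](=O)[O-])cc4)CC3)nc3ccccc32)c1` gives 24.3% in an assay on isolated protein for inhibition of aldehyde dehydrogenase 1A1 (Homo sapiens), read by spectrophotometry, tested at 10 uM; on this read-out higher numbers stand for more inhibition at the one concentration tested (going by the name of the read-out) and lower numbers for less inhibition.
Compound 2 `Cc1cccc(Cn2c(CN3CCN(C(=O)C4CCCC4)CC3)nc3ccccc32)c1` gives 67.5% in this assay.

Within the data shown here, compound 2 stands highest of the two numbers so far, and the nearest is compound 1. Among the measured compounds shown here, the one measured step, a number 43.2 percentage points higher from compound 1 to compound 2 (beyond the scatter), comes with cyclopentyl in place of 4-nitrophenyl on a carbonyl carbon, and it is large and beyond the scatter.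

Compound 3 `Cc1cccc(Cn2c(CN3CCN(C(=O)c4ccc(C(F)(F)F)cc4)CC3)nc3ccccc32)c1` has not yet been measured in this assay. It differs from compound 2 in one place: 4-(trifluoromethyl)phenyl in place of cyclopentyl on a carbonyl carbon.

The step from compound 1 to compound 2 is the only one that bears on this change, and it runs the other way: replacing an aromatic six-membered ring on the carbonyl carbon by cyclopentyl raised inhibition markedly. Compound 3 puts an aromatic six-membered ring back, though with trifluoromethyl rather than nitro, so a drop is expected, of uncertain size. Because of a number 43.2 percentage points higher from compound 1 to compound 2 (beyond the scatter), the expected step for compound 3 is a number 27.5 percentage points lower from compound 2 to compound 3 (beyond the scatter). Compound 3 is therefore estimated at 40%, with a range from 15% to 65%.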

Compound 3, a percentage reported as inhibition, at one concentration (the size of the read-out at that concentration, not a potency): 22.9%
The estimate for compound 3 lay 17.1 percentage points above the measured number, within the range that was stated.
By their numbers in this assay, from the lowest: compounds 3 and 1 (each within the scatter of the next); then compound 2.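

In this assay, the change at this position gives a number 44.6 percentage points lower from compound 2 to compound 3 (beyond the scatter), so the earlier loss with 4-nitrophenyl on the carbonyl carbon is not confined to that one aromatic cap. Trifluoromethyl in place of nitro on an aromatic carbon gives a number 1.4 percentage points lower from compound 1 to compound 3 (within the scatter), which means that among these three compounds the two substituted phenyl caps cannot be told apart, and cyclopentyl alone stands clear of them. Nothing shown here gives a measured reason for this difference between the caps.

The compounds leave open whether the difference follows the aromatic ring itself, its size, or the presence of a group on it, as cyclopentyl and the two substituted phenyl caps differ in all of these at once. An unsubstituted phenyl, a cyclohexyl or a cyclopropyl on the same carbonyl carbon would begin to separate these readings, and an amine or a carboxylic acid on the aromatic ring would test whether the tie between nitro and trifluoromethyl extends to other groups.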